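Capping the hydroxy group of compound 2

The compounds below may be only part of what the source reports. "The series", "measured", "known", "first", "only" and "open" are said of these compounds alone.

In a functional assay on HeLa cells (Homo sapiens) for cytotoxicity, read by WST assay, with a stated time of 48 h (a higher number here means a weaker inhibitor, a lower number a stronger inhibitor), compound 1 `CC[C@H](C(C)C)C(c1ccc(O)c(OC)c1)c1ccc(O)c(OC)c1` gives 9700 nM. Compound 2 `COc1cc(C(c2ccc(O)c(OC)c2)[C@H](CO)C(C)C)ccc1O` gives > 100000 nM, which is a limit and not a number. For the measured compounds named here, the only measured step, an at least 10-fold higher number from compound 1 to compound 2 (1.01 log units; beyond the scatter), is large and came with hydroxy in place of methyl on the chain. Compound 3 `COC[C@@H](C)[C@H](C)C(c1ccc(O)c(OC)c1)c1ccc(O)c(OC)c1` differs from compound 2 on a saturated chain carbon bound to two aromatic carbons: 2-(methoxymethyl)-1-methylpropyl in place of 1-(hydroxymethyl)-2-methylpropyl on a saturated chain carbon bound to two aromatic carbons. With that hydroxy gone, a lower number is expected in this assay, though its size is poorly fixed. The expected change is an at least 3.3-fold lower number from compound 2 to compound 3 (0.52 log units; beyond the scatter). Compound 3 is estimated at 30000 nM, within 8000 nM to 100000 nM.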

Compound 3, half-maximal inhibitory concentration: 58000 nM
Beside the measured number, compound 3's estimate is 1.9-fold (0.29 log units) below it; measured number inside the range.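

Capped as 2-(methoxymethyl)-1-methylpropyl, the position gives a measurable value in this assay, but the change shows only an at least 1.7-fold lower number from compound 2 to compound 3 (0.23 log units; that floor lies within the scatter). Compound 2 remains a limit and not a number: the limit of > 100000 nM in this assay, at which 1 of the 3 values shown sits. Without the free hydroxy, the chain still does not match 1-isopropylpropyl, with a 6.0-fold higher number from compound 1 to compound 3 (0.78 log units; beyond the scatter).

On these data alone, the true distance between compound 2 and compound 3 stays open. Also open, as far as these compounds go, is how this chain would read with an amine or a carboxylic acid in place of the methoxy group.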